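The source may report more compounds than this note shows. Statements on the series, on what has been measured and on what is new or still open speak of the compounds shown alone.

Working notes on the series. The shared core of compound 1 `O=C(/C=C/c1cccs1)Nc1ccc2ncnc(Nc3cccc(Br)c3)c2c1` carries an aryl group on a double-bonded chain carbon bound to a double-bonded chain carbon, and that group is the only variable so far. In a functional assay on B16-F10 cells (Mus musculus) for inhibition, read by MTT assay, with a stated time of 48 h (on this read-out higher numbers stand for weaker inhibition and lower numbers for stronger inhibition), compound 1 gives 2.51 ug/mL; the change a 1.8-fold lower number from compound 1 to compound 2 (0.26 log units; within the scatter) leads to compound 2 `Cc1ccc(/C=C/C(=O)Nc2ccc3ncnc(Nc4cccc(Br)c4)c3c2)cc1` at 1.39 ug/mL. Compound 3 `O=C(/C=C/c1ccccc1Br)Nc1ccc2ncnc(Nc3cccc(Cl)c3)c2c1` gives 1.65 ug/mL, within the scatter of compound 2 at 1.39 ug/mL and of compound 1 at 2.51 ug/mL. Compound 4 `O=C(/C=C/c1cccc2ccccc12)Nc1ccc2ncnc(Nc3cccc(Cl)c3)c2c1` differs from compound 3 by naphthalen-1-yl in place of 2-bromophenyl on a double-bonded chain carbon bound to a double-bonded chain carbon. Going by the values given here, the only measured change at this place, from compound 1 to compound 2, stayed within the scatter, so no step beyond the scatter is expected in this assay. For compound 4 the estimate is 1.6 ug/mL (range 0.8 ug/mL to 3.3 ug/mL), a step of a 1.0-fold lower number from compound 3 to compound 4 (0.01 log units; within the scatter).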

Compound 4, half-maximal inhibitory concentration: 0.671 ug/mL
Compound 4: the middle estimate sits 2.4-fold (0.38 log units) above what was measured, outside the stated range (below it).
By their numbers in this assay, from the lowest: compound 4; then compounds 2, 3 and 1 (each within the scatter of the next).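

In this assay, going by these compounds alone, naphthalen-1-yl in place of 2-bromophenyl gives a 2.5-fold lower number from compound 3 to compound 4 (0.39 log units; beyond the scatter), the first step beyond the scatter at this place. The earlier change here, between compound 1 and compound 2, stayed within the scatter, so the aryl group on a double-bonded chain carbon bound to a double-bonded chain carbon can shift this read-out. No measurement at hand bears on the reason for this step.

Where phenyl without bromine or naphthalen-2-yl would fall remains open. The added ring and the lost bromine therefore stay unseparated.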